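Ring-nitrogen exchange on a thiophene-carboxamide urea core

The source may report more compounds than this note shows. Statements on the series, on what has been measured and on what is new or still open speak of the compounds shown alone.

Measured so far in a functional assay (strain AB) with Danio rerio as the target, read by microscopy, with a stated time of 1 h; a lower number here means that less compound is needed, a higher number that more compound is needed for the effect:
compound 1, `NC(=O)c1c(NC(=O)Nc2ccc(Cl)cc2)sc2c1CCN(C1CCOCC1)C2`: 2830 nM
compound 2, `CCN1CCc2c(sc(NC(=O)[C@@H]3CCCN3)c2C(N)=O)C1`: > 25000 nM (a limit of this assay, not a number)
compound 3, `CCN1CCc2c(sc(NC(=O)Nc3ccc(Br)cc3)c2C(N)=O)C1`: 3130 nM

Among the two numbers shown, compound 1 gives the lowest; compound 3 sits nearest, within the scatter. Compound 2 returns only a limit, (the limit of > 25000 nM in this assay, at which 1 of the 3 values shown sits). The one single-place step shown is an at least 7.9-fold lower number from compound 2 to compound 3 (0.90 log units; beyond the scatter), which concerns the group on the carbonyl carbon and leaves the ring nitrogen untouched.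

Compound 4, `CC(C)(C)OC(=O)CN1CCc2c(sc(NC(=O)Nc3ccc(Cl)cc3)c2C(N)=O)C1`, differs from compound 1 at that ring nitrogen: (tert-butoxycarbonyl)methyl in place of oxan-4-yl on an amine nitrogen in a ring. Among the compounds with values here, no measured step changes this position alone. Compound 1 and compound 3 carry different groups on the ring nitrogen and different halogens, yet their values lie within the scatter of each other, so nothing shown suggests that this position moves the number strongly. Compound 4 is therefore expected to show a 1.1-fold higher number from compound 1 to compound 4 (0.03 log units; within the scatter), within the scatter. The estimated value of compound 4 is 3000 nM, between 1200 nM and 8000 nM.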

Compound 4, half-maximal effective concentration: > 25000 nM
Compound 4: a limit, no number; the forecaster's own chance of this, stated with the estimate: 10%; at least 8.3-fold (0.92 log units) between middle value and limit.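

Within the data shown here, no earlier step had touched the ring nitrogen alone, and this one shows that the position is not indifferent to what it carries: in this assay, with the rest of compound 1 unchanged, (tert-butoxycarbonyl)methyl in place of oxan-4-yl gives an at least 8.8-fold higher number from compound 1 to compound 4 (0.94 log units; beyond the scatter) on this amine nitrogen. The size of that step is a minimum and not a measured gap, since compound 4 returns a limit of the assay and not a number: the limit of > 25000 nM in this assay, at which 2 of the 4 values shown sit.

On these data alone, whether a carboxymethyl group, which is the free carboxylic acid of this ester, or a simple acetamide on the ring nitrogen would keep the number of compound 1 stays open. Also open, as far as these compounds go, is how far compound 4 lies beyond its limit.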